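The compounds below may be only part of what the source reports. "The series", "measured", "known", "first", "only" and "open" are said of these compounds alone.

In a functional assay on HT-29 cells (Homo sapiens) for inhibition, read by MTT assay, with a stated time of 48 h (a lower number here means a stronger inhibitor, a higher number a weaker inhibitor), compound 3 `CCSc1nnc(-c2cc(OC)c(OC)c(OC)c2)n1-c1ccc(N(C)C)cc1` gives only a limit, > 60000 nM. Compound 1 `COc1ccc(C(=O)CSc2nnc(-c3cc(OC)c(OC)c(OC)c3)n2-c2ccc(OC)cc2)cc1` likewise gives only a limit, > 60000 nM. Compound 2 `COc1ccc(NC(=O)CSc2nnc(-c3cc(OC)c(OC)c(OC)c3)n2-c2ccc(OC)cc2)cc1` gives a number, 45300 nM. Compound 3 therefore stands at the limit of > 60000 nM in this assay, at which 2 of the 3 values shown sit. Compound 4 `COc1cc(-c2nnc(SCC(=O)c3ccccc3)n2-c2ccc(N(C)C)cc2)cc(OC)c1OC` differs from it by benzoyl in place of methyl on a saturated chain carbon bound to a sulfur. For the measured compounds named here, no measured step covers this change. The only one, an at least 1.3-fold lower number from compound 1 to compound 2 (0.12 log units; that floor lies within the scatter), concerns a different change and offers weak guidance. In this assay, a small move to a lower number is therefore expected, with none firmly expected beyond the scatter. The expected step is an at least 1.5-fold lower number from compound 3 to compound 4 (0.17 log units; that floor lies within the scatter). Compound 4 is estimated at 40000 nM, within an expected range of 6000 nM to 100000 nM.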

Compound 4, half-maximal inhibitory concentration: 45200 nM
Estimate against measurement, compound 4: 1.1-fold (0.05 log units) below; the range from low to high includes it.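

In this assay, the change from ethylsulfanyl to (benzoylmethyl)sulfanyl gives an at least 1.3-fold lower number from compound 3 to compound 4 (0.12 log units; that floor lies within the scatter). This shows that a benzoyl on this saturated chain carbon bound to a sulfur yields a measurable number, but not that it yields a gain beyond the scatter. The true size of the step stays unknown because compound 3 gives only a limit: the limit of > 60000 nM in this assay, at which 2 of the 4 values shown sit.

From the compounds shown here alone, it remains open whether a longer chain, an amine or a carboxylic acid at this position would give a number clearly lower than that of compound 4.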